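A few compounds are considered here, and "the series" means these few. Any claim that something is new, unique, unknown or untested is made for them only; others in the source may bear on it.

Measured in a functional assay on A549 cells (Homo sapiens) for antiproliferative activity, read by MTT assay, with a stated time of 48 h (on this read-out lower numbers stand for stronger inhibition and higher numbers for weaker inhibition), so far:
compound 1 `COc1cc(-c2nnc3c(OC4COC4)cc(-c4ccc5[nH]ccc5c4)cn23)cc(OC)c1OC` gives 9810 nM
compound 2 `COc1cc(-c2nnc3c(OC)cc(-c4ccc5c(ccn5C)c4)cn23)cc(OC)c1OC` gives 69 nM
compound 3 `COc1cc(-c2nnc3c(OC(C)C)cc(-c4ccc5c(ccn5C)c4)cn23)cc(OC)c1OC` gives 322 nM

Of these three numbers, compound 3 holds the middle place, higher than compound 2 and lower than compound 1. Compound 4 `COc1cc(-c2nnc3c(OC4COC4)cc(-c4ccc5c(ccn5C)c4)cn23)cc(OC)c1OC` has oxetan-3-yl in place of isopropyl on an oxygen on an aromatic ring. Among the measured compounds shown here, one measured step bears directly on this oxygen, a 4.7-fold higher number from compound 2 to compound 3 (0.67 log units; beyond the scatter), where isopropyl replaces methyl. For the measured compounds named here, no measured step exchanges isopropyl for oxetan-3-yl. Compound 1 also carries oxetan-3-yl and gives 9810 nM, but it differs from compound 4 elsewhere as well, so that value cannot be credited to the group alone. It does leave some risk on the high side. In this assay a small shift towards a higher number is therefore expected, possibly none beyond the scatter. The expected change is a 1.4-fold higher number from compound 3 to compound 4 (0.15 log units; within the scatter) in size. Compound 4 is estimated at 450 nM (expected range 120 nM to 2000 nM).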

Compound 4, half-maximal inhibitory concentration: 516 nM
Compound 4: the middle estimate sits 1.1-fold (0.06 log units) below what was measured; measured number inside the range.
By their numbers in this assay, from the lowest: compound 2; then compounds 3 and 4 (each within the scatter of the next); then compound 1.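

In this assay, oxetan-3-yl on this oxygen gives a result within the scatter of isopropyl, with a 1.6-fold higher number from compound 3 to compound 4 (0.20 log units; within the scatter), while the step from methyl, a 7.5-fold higher number from compound 2 to compound 4 (0.87 log units; beyond the scatter), lies beyond it. The oxetan-3-yl group alone therefore does not account for the high number of compound 1: with that group held constant, a 19-fold lower number from compound 1 to compound 4 (1.28 log units; beyond the scatter) accompanies methyl in place of hydrogen on the aromatic nitrogen. No supporting data explain why either change has the size it does.

Going by these compounds, it remains open whether a small group such as ethyl, or a chain ending in an amine, would stay close to compound 2 at this oxygen. On these data alone, it also remains open whether hydrogen on the aromatic nitrogen would cost as much with methyl on the oxygen.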